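Turning the Double Bond: From Compound 3 to Compound 4

This account rests on a few compounds, and the source may have more. Where it says the series, first, only, none or still open, it means among the compounds named here.

Measured so far in a functional assay on SW1573 cells (Homo sapiens) for inhibition, read by sulforhodamine B assay, with a stated time of 48 h; on this read-out lower numbers stand for stronger inhibition of growth and higher numbers for weaker inhibition of growth:
- compound 1, `CC(=O)OC/C(=C\C1CCCCC1)C(=O)c1ccc(Cl)cc1`, gives 18000 nM
- compound 2, `CC(=O)OC/C(=C\c1ccc(Cl)cc1)C(=O)c1ccc(Cl)cc1`, gives 3400 nM
- compound 3, `CC(=O)OC/C(=C\c1ccc(Cl)cc1Cl)C(=O)c1ccc(Cl)cc1`, gives 3400 nM

Compound 3 stands level with compound 2 at the digits recorded, and together they give the lowest numbers of the three, as shown by no change at the digits printed from compound 2 to compound 3 (within the scatter). Compound 1 is the furthest away: a 5.3-fold lower number from compound 1 to compound 3 (0.72 log units; beyond the scatter).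

Compound 4, `CC(=O)OC/C(=C/c1ccc(Cl)cc1Cl)C(=O)c1ccc(Cl)cc1`, differs from compound 3 only in drawn geometry: the two compounds have the same atoms and bonds and differ only in configuration as drawn: 1 of 1 stereo elements differ; a double bond is drawn E in compound 3 and Z in compound 4.

Going by the values given here, none of the measured steps touches this kind of change. The steps of a 5.3-fold lower number from compound 1 to compound 2 (0.72 log units; beyond the scatter) and a 5.3-fold lower number from compound 1 to compound 3 (0.72 log units; beyond the scatter) swapped a cyclohexyl for a chlorinated phenyl, and no change at the digits printed from compound 2 to compound 3 (within the scatter) added one chloro; all three kept the double bond drawn E. There is therefore no direct guide to the size or direction of the step from compound 3 to compound 4 in this assay.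

For compound 4 the expectation is a number close to that of compound 3, giving 4000 nM with a range from 1200 nM to 14000 nM, which is an estimated step of a 1.2-fold higher number from compound 3 to compound 4 (0.07 log units; within the scatter).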

Compound 4, concentration for 50% growth inhibition: 21000 nM
The estimate for compound 4 lay 5.3-fold (0.72 log units) below the measured number, outside the stated range (above it).
By their numbers in this assay, from the lowest: compounds 2 and 3 (each within the scatter of the next); then compounds 1 and 4 (each within the scatter of the next).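

In this assay, turning the double bond from E to Z gives a 6.2-fold higher number from compound 3 to compound 4 (0.79 log units; beyond the scatter), so the arrangement around this bond counts for growth inhibition even with every atom kept in place. The earlier steps shown here exchanged or added groups while the bond stayed drawn E, and the added chloro, for one, gave no change at the digits printed from compound 2 to compound 3 (within the scatter); they could say nothing about geometry. This step can be laid on the geometry alone because nothing else separates the pair: the fact that compounds 3 and 4 differ only in the configuration as drawn.

Still open, on these data alone, is whether the same turn has a similar effect with 4-chlorophenyl or cyclohexyl on the double bond, as the E and Z pair here carries 2,4-dichlorophenyl. Also open, as far as these compounds go, is how either geometry would fare with an amine or a carboxylic acid in place of that group.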